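This account rests on a few compounds, and the source may have more. Where it says the series, first, only, none or still open, it means among the compounds named here.

Measured compounds:
compound 1, `CC#CCn1c(N2CCC[C@@H](N)C2)cc(=O)n(Cc2cccc(C(=O)O)c2Br)c1=O`: "not determined" (no result reported)
compound 2, `CC#CCn1c(N2CCC[C@@H](N)C2)cc(=O)n(Cc2ccc(F)c(C(=O)OC)c2)c1=O`: > 100 nM

Two compounds share one core and differ only in the aromatic group carried on a saturated chain carbon bound to an aromatic nitrogen. In an assay on isolated protein for inhibition of Dipeptidyl peptidase 9 (Homo sapiens), read by fluorescence, with stated times of 15 min and 20 min (a lower number here means a stronger inhibitor, a higher number a weaker inhibitor), compound 1 has no result, only "not determined" (no result reported). For compound 2 the reported result in this assay is a limit and not a number, > 100 nM. Compound 2 therefore sits at the limit of > 100 nM in this assay, at which 1 of the 2 values shown sits. Among the compounds with values here, no measured step links the two, so no direction or size of change can be read from them. Compound 3, `CC#CCn1c(N2CCC[C@@H](N)C2)cc(=O)n(Cc2ccc(Br)c(C(=O)O)c2)c1=O`, differs from compound 1 by 4-bromo-3-carboxyphenyl in place of 2-bromo-3-carboxyphenyl on a saturated chain carbon bound to an aromatic nitrogen. Compound 1 has no number in this assay. The step from compound 1 to compound 3 cannot be sized from the data. Compound 3 is therefore only estimated, at 300 nM in this assay, within a wide range from 30 nM to 3000 nM, and a further limit instead of a number is a real possibility.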

Compound 3, half-maximal inhibitory concentration: > 100 nM
Compound 3 was reported as a limit (the forecaster's own chance of this, stated with the estimate: 40%); the middle value lies beyond the limit too.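

In this assay compound 3 gives > 100 nM, a limit and not a number, so no new step can be read between it and compound 1 or compound 2. From the compounds shown here alone, what stays open is how strongly each of the three compounds actually inhibits this enzyme, and whether 4-bromo-3-carboxyphenyl and 2-bromo-3-carboxyphenyl differ at all.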